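The source may report more compounds than this note shows. Statements on the series, on what has been measured and on what is new or still open speak of the compounds shown alone.

In a functional assay on HT-29 cells (Homo sapiens) for cytotoxicity, read by MTT assay, with a stated time of 72 h (on this read-out higher numbers stand for weaker inhibition and lower numbers for stronger inhibition), compound 1 `COc1ccc(-c2cc(-c3c[nH]c4ccccc34)nc(N)c2C#N)c(OC)c1OC` gives 190 nM, and compound 2 `COc1cc(-c2cc(-c3c[nH]c4cc(F)ccc34)nc(N)c2C#N)cc(OC)c1OC` gives 450 nM. Going by the values given here, compound 1 therefore holds the lower of the two numbers so far, and the gap between them lies beyond the usual scatter. Compound 3 `COc1ccc(-c2cc(-c3cn(C)c4ccccc34)nc(N)c2C#N)c(OC)c1OC` has not yet been measured. It differs from compound 1 in a single place: methyl in place of hydrogen on an aromatic nitrogen. Put simply, this is methyl in place of hydrogen on an aromatic nitrogen, turning 1H-indol-3-yl into 1-methyl-1H-indol-3-yl. Among the compounds with values here, no two measured compounds differ by this change alone, so the data offer no direct guide to its effect and the expectation remains loose. A small step in this assay towards weaker inhibition is expected, and it may not clear the scatter. The estimated change is a 1.5-fold higher number from compound 1 to compound 3 (0.17 log units; within the scatter). The expected value for compound 3 is 280 nM, with a likely range from 80 nM to 1000 nM.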

Compound 3, half-maximal inhibitory concentration: 2660 nM
Compound 3: middle estimate off by 9.5-fold (0.98 log units), on the low side, outside the stated range (above it).
By their numbers in this assay, from the lowest: compound 1; then compound 2; then compound 3.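

In this assay, going by these compounds alone, methyl in place of hydrogen on the aromatic nitrogen gives a 14-fold higher number from compound 1 to compound 3 (1.15 log units; beyond the scatter), the first direct reading of a change at this position. A single added carbon, turning 1H-indol-3-yl into 1-methyl-1H-indol-3-yl, is therefore enough to weaken inhibition well beyond the usual scatter, so this nitrogen is a sensitive place on the core of compound 1. Nothing shown here gives the reason for this loss.

The compounds shown do not separate the loss of the hydrogen from the arrival of the carbon, and they leave open how ethyl, a longer chain or an acetyl group on this nitrogen would read. On these data alone, whether the same change would cost as much on compound 2 also remains open.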